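Swapping Hydroxy for Amino: What to Expect of Compound 4

A few compounds are considered here, and "the series" means these few. Any claim that something is new, unique, unknown or untested is made for them only; others in the source may bear on it.

Compound 1 `COc1ccc(-c2cc(-c3ccccc3-c3ccccc3)n[nH]2)cc1` gives 670 nM in a functional assay on OVCAR cells (Homo sapiens) for inhibition, read by MTT assay, with a stated time of 48 h; a higher number here means a weaker inhibitor of growth, a lower number a stronger inhibitor of growth
Compound 2 `COc1ccccc1-c1cc(-c2ccccc2-c2ccccc2)n[nH]1` gives 14200 nM in this assay
Compound 3 `Oc1ccc(-c2cc(-c3ccccc3-c3ccccc3)n[nH]2)cc1` gives 6200 nM in this assay

Compound 3 stands second highest of the three numbers in this assay: its nearest neighbour is compound 2, a step of a 2.3-fold lower number from compound 2 to compound 3 (0.36 log units; beyond the scatter), and its furthest is compound 1, from which it is separated by a 9.3-fold higher number from compound 1 to compound 3 (0.97 log units; beyond the scatter). Compound 4 `Nc1ccc(-c2cc(-c3ccccc3-c3ccccc3)n[nH]2)cc1` has not yet been measured; it differs from compound 3 by amino in place of hydroxy on an aromatic carbon. Among the compounds with values here, none of the measured steps exchanges one single heavy atom for another at this position. The step of a 9.3-fold higher number from compound 1 to compound 3 (0.97 log units; beyond the scatter) shows that a change on the oxygen at this place matters, while a 21-fold higher number from compound 1 to compound 2 (1.33 log units; beyond the scatter) shows that moving the group around the ring matters far more. Since the amino group brings the same count of donors and acceptors as the hydroxy it replaces, compound 4 is expected to sit close to compound 3, with a step of about a 1.4-fold lower number from compound 3 to compound 4 (0.14 log units; within the scatter). The estimate for compound 4 in this assay is therefore 4500 nM, within a range of 1200 nM to 17000 nM.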

Compound 4, concentration for 50% growth inhibition: 17900 nM
Estimate against measurement, compound 4: 4.0-fold (0.60 log units) below; the whole stated range lies below it.
By their numbers in this assay, from the lowest: compound 1; then compound 3; then compounds 2 and 4 (each within the scatter of the next).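

In this assay, exchanging hydroxy for amino at this place is not a neutral swap: a 2.9-fold higher number from compound 3 to compound 4 (0.46 log units; beyond the scatter) separates two groups that each have one heavy atom and the same counts of hydrogen-bond donors and acceptors. Measured against the methoxy group of compound 1, the amino group gives a much wider gap, a 27-fold higher number from compound 1 to compound 4 (1.43 log units; beyond the scatter) on this change, while a 1.3-fold higher number from compound 2 to compound 4 (0.10 log units; within the scatter) leaves compound 4 and compound 2 indistinguishable despite their different substitution. No measurement available here accounts for the difference between amino and hydroxy.

The compounds shown leave open whether the gap to compound 1 depends on the methyl carried by the oxygen, which ethoxy or dimethylamino at this place could test. They also leave open how a group with neither oxygen nor nitrogen, such as methyl or chlorine, would read here.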